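The source may report more compounds than this note shows. Statements on the series, on what has been measured and on what is new or still open speak of the compounds shown alone.

Of the compounds shown here, two from the same series carry numbers so far, and both share a core built from a six-membered non-aromatic ring with one nitrogen fused to a benzene ring, with an amide arm on the ring carbon. Compound 1, `O=C(Nc1ccccc1O)C1CCc2ccccc2N1C(=O)c1ccc(Cl)cc1`, and compound 2, `CCCC(=O)N1c2ccccc2CCC1C(=O)Nc1cc(C(F)(F)F)cc(C(F)(F)F)c1`, were both tested in a functional assay on NUGC-3 cells (Homo sapiens) for cytotoxicity, read by sulforhodamine B assay, with a stated time of 72 h; on this read-out lower numbers stand for stronger inhibition of growth and higher numbers for weaker inhibition of growth. In this assay compound 1 gives 13400 nM, and compound 2 gives 14400 nM; these two readings lie within the scatter of each other, so neither can be called stronger than the other.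

The next compound, compound 3, `O=C(Nc1ccccc1O)C1CCc2ccccc2N1`, has not been measured. It differs from compound 1 by one change: hydrogen in place of (4-chlorophenyl)carbonyl on a nitrogen on an aromatic ring in a ring. The ring nitrogen thus loses its acyl group and carries a hydrogen instead, while the amide to the hydroxyphenyl group is kept. Within the data shown here, no measured pair shows what this kind of change does here, so the expectation rests only on the weak growth inhibition of compound 1. With a large group removed, compound 3 is expected to inhibit growth somewhat less, a step of a 2.2-fold higher number from compound 1 to compound 3 (0.35 log units; beyond the scatter), giving an estimated 30000 nM with a range from 8000 nM to 100000 nM.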

Compound 3, concentration for 50% growth inhibition: 2680 nM
Compound 3: the middle estimate sits 11-fold (1.05 log units) above what was measured, outside the stated range (below it).
By their numbers in this assay, from the lowest: compound 3; then compounds 1 and 2 (each within the scatter of the next).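

Replacing the (4-chlorophenyl)carbonyl group on the ring nitrogen with a hydrogen gives a 5.0-fold lower number from compound 1 to compound 3 (0.70 log units; beyond the scatter) in this assay, so in this pair the large group is not needed for growth inhibition, and the compound without it does better. Among these compounds, this is the first measured change at this nitrogen, and it shows that the position responds clearly to what it carries, with the hydrogen-bearing form ahead of the form with the aromatic acyl group. Nothing available explains why the number moves in this direction.

Among the compounds shown here, this single pair compares only one acyl group with a hydrogen, so it remains open whether a smaller group on the same nitrogen, such as a methyl or an acetyl, would behave more like the hydrogen of compound 3 or more like the (4-chlorophenyl)carbonyl of compound 1. For the compounds shown here, it also remains open whether the same change would have a similar effect with a different amide arm, such as the one carried by compound 2, whose butanoyl group and arm both differ from those of compound 1.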